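Carbamate in place of the neopentyl ester in the core of compound 2

A few compounds are considered here, and "the series" means these few. Any claim that something is new, unique, unknown or untested is made for them only; others in the source may bear on it.

Measured so far:
compound 1 `CCCCCCCCCCCCCCCCCC(=O)OCC1CN(C(=O)c2cc(OC)c(OC)c(OC)c2)CCN1C(=O)c1cc(OC)c(OC)c(OC)c1`: 45000 nM
compound 2 `COc1cc(C(=O)N2CCN(C(=O)c3cc(OC)c(OC)c(OC)c3)C(COC(=O)CC(C)(C)C)C2)cc(OC)c1OC`: 120 nM
compound 3 `COc1cc(N2CCN(c3cc(OC)c(OC)c(OC)c3)CC2)cc(OC)c1OC`: 12500 nM

In a functional assay (Oryctolagus cuniculus) for inhibition of platelet-activating factor receptor (Cavia porcellus) (on this read-out higher numbers stand for weaker inhibition and lower numbers for stronger inhibition), compound 2 gives the lowest of the three numbers; compound 3 stands above it by a gap beyond the scatter, and compound 1 stands furthest from it, also beyond the scatter. Compound 4 `CCCCCCCCNC(=O)OCC1CN(C(=O)c2cc(OC)c(OC)c(OC)c2)CCN1C(=O)c1cc(OC)c(OC)c(OC)c1` differs from compound 2 by octylamino in place of neopentyl on a carbonyl carbon. For the measured compounds named here, no step between measured compounds covers this change. Since the long-chain ester of compound 1 gives 45000 nM, a weakening step is expected, a 13-fold higher number from compound 2 to compound 4 (1.10 log units; beyond the scatter), though smaller than that. Compound 4 is estimated at 1500 nM, with a range from 250 nM to 10000 nM.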

Compound 4, half-maximal inhibitory concentration: 370 nM
The estimate for compound 4 lay 4.1-fold (0.61 log units) above the measured number, and the stated range covers the measured number.
By their numbers in this assay, from the lowest: compound 2; then compound 4; then compound 3; then compound 1.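

In this assay, the carbonyl carbon of the side chain accepts octylamino in place of neopentyl at a modest cost, a 3.1-fold higher number from compound 2 to compound 4 (0.49 log units; beyond the scatter). A long chain at this place is thus compatible with a value far lower than that of the long-chain ester: compound 1 gives 45000 nM and compound 4 gives 370 nM. No data on hand account for the step.

The carbamate link and the octyl chain enter together, so their contributions remain unseparated. An octanoyl ester or a neopentylamino carbamate would tell them apart.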